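Replacing ureido with piperazin-1-yl on the shared core

The compounds below may be only part of what the source reports. "The series", "measured", "known", "first", "only" and "open" are said of these compounds alone.

Values measured in a functional assay on SK-MEL-28 cells (Homo sapiens) for cytotoxicity, read by MTT assay, with a stated time of 3 days (on this read-out lower numbers stand for stronger inhibition and higher numbers for weaker inhibition), follow
Compound 1 `N#Cc1c(NNC(N)=S)nc(SCc2nc3ccccc3[nH]2)nc1-c1ccccc1` gives 3.2 nM
Compound 2 `N#Cc1c(NC(N)=S)nc(SCc2nc3ccccc3[nH]2)nc1-c1ccccc1` gives 4.8 nM
Compound 3 `N#Cc1c(NC(N)=O)nc(SCc2nc3ccccc3[nH]2)nc1-c1ccccc1` gives 4.8 nM

Compound 3 stands level with compound 2 at the digits shown, and within the scatter of compound 1. Compound 4 `N#Cc1c(-c2ccccc2)nc(SCc2nc3ccccc3[nH]2)nc1N1CCNCC1` carries piperazin-1-yl in place of ureido on an aromatic carbon. Among the compounds with values here, three measured steps bear on this place: (a 1.5-fold higher number from compound 1 to compound 2 (0.18 log units; within the scatter)), (a 1.5-fold higher number from compound 1 to compound 3 (0.18 log units; within the scatter)) and (no change at the digits printed from compound 2 to compound 3 (within the scatter)). All stay within the scatter, yet none brings a ring there, so the evidence is indirect. In this assay no step beyond the scatter is expected, only a slight lean to a higher number (a 1.5-fold higher number from compound 3 to compound 4 (0.16 log units; within the scatter)). For compound 4 the estimated value is 7 nM (range 2 nM to 30 nM).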

Compound 4, half-maximal inhibitory concentration: 2.6 nM
Compound 4: the middle estimate sits 2.7-fold (0.43 log units) above what was measured; the range from low to high includes it.
By their numbers in this assay, from the lowest: compounds 4, 1, 2 and 3 (each within the scatter of the next).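

In this assay, within the data shown here, this aromatic carbon carries a ring as well as the open groups of the earlier compounds: piperazin-1-yl gives no step beyond the scatter against any of them (a 1.8-fold lower number from compound 3 to compound 4 (0.27 log units; within the scatter); a 1.8-fold lower number from compound 2 to compound 4 (0.27 log units; within the scatter); a 1.2-fold lower number from compound 1 to compound 4 (0.09 log units; within the scatter)). The ureido hydrogen-bond donor count is therefore not tied to the value here, since one fewer donor enters with the ring in compound 4. Nothing measured here explains this result. The compounds shown leave open whether a morpholin-4-yl ring or a carboxylic acid at this place would also stay within the scatter in this assay.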